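This account rests on a few compounds, and the source may have more. Where it says the series, first, only, none or still open, it means among the compounds named here.

Compound 1 `COc1cc(/C=C/C2=CC(=O)CC(c3ccc(O)c(OC)c3)N2CCCO)ccc1O` gives 62900 nM 
Compound 2 `O=C(/C=C(/C=C/c1ccc(O)cc1)NCCCO)/C=C/c1ccc(O)cc1` gives 128000 nM 

In a physicochemical assay for solubility, using the shake flask method, in phosphate buffer, with a stated time of 24 h, at pH 6.8 (on this read-out higher numbers stand for higher solubility and lower numbers for lower solubility), compound 2 stands at 128000 nM as the higher of the two numbers, and the gap down to compound 1 lies beyond the usual scatter. Compound 3 `COCCNC(=C\C(=O)/C=C/c1ccc(O)cc1)/C=C/c1ccc(O)cc1` has not yet been measured. It differs from compound 2 by a single change (methoxy in place of hydroxymethyl on a saturated chain carbon, two bonds along the chain from an amine nitrogen), with methoxy in place of hydroxymethyl on a saturated chain carbon, two bonds along the chain from an amine nitrogen. Going by the values given here, no measured pair shows this change, so the expectation rests on the structures alone. A small downward move in this assay is expected, probably not beyond the scatter, and the estimated step (a 1.4-fold lower number from compound 2 to compound 3 (0.15 log units; within the scatter)) is modest. Compound 3 is estimated at 90000 nM in this read-out, with 40000 nM as the lower end and 200000 nM as the upper end of the expected range.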

Compound 3, solubility: 46100 nM
Estimate against measurement, compound 3: 2.0-fold (0.29 log units) above; measured number inside the range.
By their numbers in this assay, from the lowest: compounds 3 and 1 (each within the scatter of the next); then compound 2.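

Going by these compounds alone, the first step at this position shows that the chain on the nitrogen is not a silent spot in this assay. Replacing hydroxymethyl with methoxy on a saturated chain carbon, two bonds along the chain from an amine nitrogen, gives a 2.8-fold lower number from compound 2 to compound 3 (0.44 log units; beyond the scatter), a move larger than the usual scatter even though both groups hold 2 heavy atoms and the swap takes the count of hydrogen-bond donors in that group from 1 to 0. Nothing measured here explains why the number moves.

This single pair cannot show whether the same swap would act alike on the core of compound 1. It also leaves open what a carboxylic acid, an amine or a longer chain in place of the hydroxymethyl would give.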